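Methyl on the benzoyl group of compound 1

This account rests on a few compounds, and the source may have more. Where it says the series, first, only, none or still open, it means among the compounds named here.

For the measured compounds named here, in a functional assay on IMR-32 cells (Homo sapiens) for antiproliferative activity, with a stated time of 72 h (on this read-out higher numbers stand for weaker inhibition and lower numbers for stronger inhibition), compound 1 (`O=C(CCN(Cc1ccc(C(=O)NO)cc1)C(=O)c1ccccc1)NCc1ccccc1`) gives 2360 nM, the highest of the three numbers measured so far. Compound 3 (`Cc1ccc(NC(=O)CCN(Cc2ccc(C(=O)NO)cc2)C(=O)c2ccccc2)cc1`) gives 550 nM, and compound 2 (`Cc1ccc(CNC(=O)CCN(Cc2ccc(C(=O)NO)cc2)C(=O)c2ccc(N(C)C)cc2)cc1`) gives 260 nM. Compound 4 (`Cc1ccc(C(=O)N(CCC(=O)NCc2ccccc2)Cc2ccc(C(=O)NO)cc2)cc1`) awaits measurement and differs from compound 1 by methyl in place of hydrogen on an aromatic carbon. Going by the values given here, no measured step covers this change alone, and compound 2 differs from compound 1 in more than one place. The nearest guide is a 4.3-fold lower number from compound 1 to compound 3 (0.63 log units; beyond the scatter), a change elsewhere on the molecule, so only a smaller step towards lower numbers is expected, within the scatter or close to it. The expected step is a 1.6-fold lower number from compound 1 to compound 4 (0.20 log units; within the scatter). For compound 4 the estimated value is 1500 nM, with an expected range from 700 nM to 3000 nM.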

Compound 4, half-maximal inhibitory concentration: 630 nM
Estimate against measurement, compound 4: 2.4-fold (0.38 log units) above, outside the stated range (below it).
By their numbers in this assay, from the lowest: compound 2; then compounds 3 and 4 (each within the scatter of the next); then compound 1.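

In this assay, the change from phenyl to 4-methylphenyl on the benzoyl group gives a 3.7-fold lower number from compound 1 to compound 4 (0.57 log units; beyond the scatter) on its own, so this ring position responds to a single added carbon. Compound 3 had shown a step from a change elsewhere on the molecule; this is the first single change read at this position. Nothing available here accounts for the step.

Going by these compounds, whether other groups on this aromatic carbon, such as methoxy, chlorine or ethyl, would move the number likewise stays open. So does how the methyl behaves on the core of compound 3.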